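The source may report more compounds than this note shows. Statements on the series, on what has been measured and on what is new or still open speak of the compounds shown alone.

Measured compounds:
compound 1 `COc1ccc(N2CCN(Cc3csc(N)c3C(=O)c3ccc(Cl)cc3)CC2)cc1` — 0%
compound 2 `Nc1scc(CN2CCN(c3cccc4ccccc34)CC2)c1C(=O)c1ccc(Cl)cc1` — 0%
compound 3 `Nc1scc(CN2CCN(c3cc(F)ccc3F)CC2)c1C(=O)c1ccc(Cl)cc1` — 2%

In an assay on CHO cells for displacement of a labelled ligand from adenosine receptor A3 (Homo sapiens), read by scintillation counting, with a stated time of 120 min, tested at 10 uM (a higher number here means more inhibition at the concentration tested (going by the name of the read-out), a lower number less inhibition), compound 3 gives 2%, on the numbers shown the largest figure of the three, but the step of a number 2 percentage points higher from compound 1 to compound 3 (within the scatter) and the step of a number 2 percentage points higher from compound 2 to compound 3 (within the scatter) both lie within the scatter, so the three compounds are not told apart by this assay. Compound 4 `Nc1scc(CN2CCN(c3c(Cl)cccc3Cl)CC2)c1C(=O)c1ccc(Cl)cc1` differs from compound 3 in one place: 2,6-dichlorophenyl in place of 2,5-difluorophenyl on an amine nitrogen in a ring. The measured steps that bear on this change are the exchanges of the aryl group on the same ring nitrogen: no change at the digits printed from compound 1 to compound 2 (within the scatter), a number 2 percentage points higher from compound 1 to compound 3 (within the scatter) and a number 2 percentage points higher from compound 2 to compound 3 (within the scatter). Going by the values given here, every one of these exchanges left the read-out within the scatter, and nothing among the measured compounds separates one aryl group on that nitrogen from another. The step of no change at the digits printed from compound 3 to compound 4 (within the scatter) is therefore expected to stay within the scatter, with no direction to it. Compound 4 is estimated at 2%, with a range from 0% to 12%.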

Compound 4, a percentage reported as inhibition, at one concentration (the size of the read-out at that concentration, not a potency): 1%
Compound 4: the middle estimate sits 1 percentage points above what was measured; the range from low to high includes it.
By their numbers in this assay, from the lowest: compounds 1, 2, 4 and 3 (each within the scatter of the next).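

In this assay the exchange of 2,5-difluorophenyl for 2,6-dichlorophenyl gives a number 1 percentage points lower from compound 3 to compound 4 (within the scatter), while the exchanges from the other two aryl groups give a number 1 percentage points higher from compound 2 to compound 4 (within the scatter) and a number 1 percentage points higher from compound 1 to compound 4 (within the scatter). The read-out on this ring nitrogen therefore stays within the scatter for a fourth aryl group, now one carrying chlorine rather than fluorine, methoxy or a fused second ring, so the flat picture extends to this new substitution and still gives no ordering among these aryl groups. No supporting evidence accompanies this result that could account for it. The compounds shown leave open whether a non-aryl group on this nitrogen, such as a benzyl or acetyl group, would shift the read-out. They also leave open whether placing an amine or a carboxylic acid elsewhere on the shared core would do so.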